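Phenylalkanoyl lactam amides: chain homologues and cytotoxicity

A few compounds are considered here, and "the series" means these few. Any claim that something is new, unique, unknown or untested is made for them only; others in the source may bear on it.

Compound 1 `O=C(CCCCCc1ccccc1)N[C@H]1CCOC1=O` and compound 3 `O=C(CCCCCCc1ccccc1)N[C@H]1CCOC1=O` share a core and differ by benzyl in place of phenyl on a saturated chain carbon, five bonds along the chain from a carbonyl carbon. In a functional assay on NCI-H630 cells (Homo sapiens) for cytotoxicity, read by sulforhodamine B assay, with a stated time of 5 days (on this read-out lower numbers stand for stronger inhibition and higher numbers for weaker inhibition), compound 1 gives > 100000 nM, which is a limit of the assay and not a number. In this assay compound 3 gives > 100000 nM, again a limit. The step that the two limits leave unreadable from compound 1 to compound 3 therefore cannot be sized, as all three reported values rest at the limit of > 100000 nM in this assay, at which 3 of the 3 values shown sit. Compound 2 `O=C(CCCCCCCCc1ccccc1)N[C@H]1CCOC1=O` differs from compound 1 in more than one place, and the difference between the two cores is not broken down here. In this assay compound 2 gives > 100000 nM, a limit as well. Compound 4 `O=C(CCCCCCCCCc1ccccc1)N[C@H]1CCOC1=O` is not yet measured; it differs from compound 2 by benzyl in place of phenyl on a saturated chain carbon, eight bonds along the chain from a carbonyl carbon. This is the same kind of change as that from compound 1 to compound 3, though the place differs: five bonds along the chain from a carbonyl carbon there, eight bonds along the chain from a carbonyl carbon here. Since compound 1, compound 2 and compound 3 all sit at the limit of > 100000 nM in this assay, at which 3 of the 3 values shown sit, the step that the limit leaves unreadable from compound 2 to compound 4 is expected to stay unreadable, with compound 4 most likely at the limit too. The estimate for compound 4 in this assay is 150000 nM.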

Compound 4, half-maximal inhibitory concentration: > 100000 nM
Compound 4 ended at the assay's limit; the forecaster's own chance of this, stated with the estimate: 85%; the middle value lies beyond the limit too.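

In this assay compound 4 gives > 100000 nM, a limit of the assay and not a number. No step can be read from compound 2 to compound 4, as both rest at a limit: the limit of > 100000 nM in this assay, at which 4 of the 4 values shown sit.

The compounds shown leave open how the chain homologues rank against one another and whether chain length matters at all in this series.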